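Swapping a methoxyphenyl for a pyrimidine on a ghrelin agonist

A few compounds are considered here, and "the series" means these few. Any claim that something is new, unique, unknown or untested is made for them only; others in the source may bear on it.

Measured so far:
- compound 1 `C[C@@H]1CN(c2cccc(NS(=O)(=O)c3ccc(-c4ccccn4)s3)c2)C[C@H](C)N1`: 39.8 nM
- compound 2 `COc1cccc(-c2ccc(S(=O)(=O)Nc3cc(N4C[C@@H](C)N[C@@H](C)C4)ccc3OC)cc2)c1`: 2 nM

In a functional assay for agonist activity at growth hormone secretagogue receptor type 1 (Homo sapiens), read by FLIPR (a higher number here means that more compound is needed for the effect, a lower number that less compound is needed), compound 2 gives 2 nM, the lower of the two numbers, while compound 1 gives 39.8 nM. Compound 3 `COc1ccc(N2C[C@@H](C)N[C@@H](C)C2)cc1NS(=O)(=O)c1ccc(-c2cncnc2)cc1` keeps everything in compound 2 except one change: pyrimidin-5-yl in place of 3-methoxyphenyl on an aromatic carbon. Among the measured compounds shown here, no measured pair shows this change, so its effect is unknown. Compound 3 is expected to need somewhat more compound than compound 2, a step of a 3.0-fold higher number from compound 2 to compound 3 (0.48 log units; beyond the scatter) in this assay, beyond the scatter but not large. Compound 3 is estimated at 6 nM, with a range from 1.5 nM to 30 nM.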

Compound 3, half-maximal effective concentration: 316 nM
Compound 3: middle estimate off by 53-fold (1.72 log units), on the low side, and the stated range ends below it.
By their numbers in this assay, from the lowest: compound 2; then compound 1; then compound 3.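

In this assay, this position, para to a large group, proves highly sensitive: pyrimidin-5-yl in place of 3-methoxyphenyl gives a 160-fold higher number from compound 2 to compound 3 (2.20 log units; beyond the scatter), a large change from a single swap. One six-membered aromatic ring therefore cannot simply stand in for another here. No measurement at hand explains the change.

Still open, going by these compounds, is whether the two ring nitrogens or the missing methoxy matters more. An unsubstituted phenyl or a pyridin-3-yl at this position would help to separate the two.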